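The compounds below may be only part of what the source reports. "The series", "measured", "known", "first", "only" and "open" are said of these compounds alone.

In a functional assay on HeLa cells (Homo sapiens) for inhibition, read by CCK-8 assay, with a stated time of 48 h (a higher number here means a weaker inhibitor, a lower number a stronger inhibitor), compound 1 `COc1cc(-c2ccnc3cc(-c4c[nH]c5ccccc45)nn23)cc(OC)c1OC` gives 195 nM, at the low end of the numbers measured, and compound 2 `COc1cc(-c2ccnc3cc(-c4ccc(N(C)C)cc4)nn23)cc(OC)c1OC` gives 378 nM, level with it within the scatter. Compound 3 `COc1cc(-c2ccnc3cc(-c4ccc(C(C)=O)cc4)nn23)cc(OC)c1OC` gives 1810 nM. Compound 4 `COc1cc(-c2ccnc3cc(-c4cn(C(=O)OC(C)(C)C)c5ccccc45)nn23)cc(OC)c1OC` differs from compound 1 by tert-butoxycarbonyl in place of hydrogen on an aromatic nitrogen. Going by the values given here, no measured step tests that change directly. The nearest evidence comes from replacing the whole 1H-indol-3-yl group, which gave a 1.9-fold higher number from compound 1 to compound 2 (0.29 log units; within the scatter) and a 9.3-fold higher number from compound 1 to compound 3 (0.97 log units; beyond the scatter). On that slender basis, a modest move to a higher number is expected in this assay, with an estimated size of a 2.8-fold higher number from compound 1 to compound 4 (0.45 log units; beyond the scatter). Compound 4 is expected to give 550 nM, with an estimated range of 170 nM to 1800 nM.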

Compound 4, half-maximal inhibitory concentration: 3770 nM
The estimate for compound 4 lay 6.9-fold (0.84 log units) below the measured number; the measured number lies above the stated range.
By their numbers in this assay, from the lowest: compounds 1 and 2 (each within the scatter of the next); then compound 3; then compound 4.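

The earlier compounds shown here replaced the whole 1H-indol-3-yl group, whereas here that group stays and only the hydrogen on its aromatic nitrogen is replaced in this assay, with a 19-fold higher number from compound 1 to compound 4 (1.29 log units; beyond the scatter) for tert-butoxycarbonyl in its place. A change at this nitrogen alone, with the rest of compound 1 untouched, is therefore enough to produce a large step in this assay. Nothing available explains the size of this step. The compounds shown leave open whether a methyl or an acetyl on the same nitrogen would stay closer to compound 1 or also give a large step.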